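The source may report more compounds than this note shows. Statements on the series, on what has been measured and on what is new or still open speak of the compounds shown alone.

Three compounds have been measured in a functional assay on HEK293 cells for negative allosteric modulation of metabotropic glutamate receptor 5 (Rattus norvegicus), read by FLIPR and calcium flux, with a stated time of 170 s; a lower number here means a stronger inhibitor, a higher number a weaker inhibitor:

Compound 1 `c1ccc(-c2cc3n(n2)CCCC3)nc1`: 1290 nM
Compound 2 `Clc1ccc(-c2cc3n(n2)CCCC3)nc1`: 669 nM
Compound 3 `c1ccc(COc2cc3n(n2)CCCC3)nc1`: 2500 nM

Compound 2 differs from compound 1 by chloro in place of hydrogen on an aromatic carbon. That change gave a 1.9-fold lower number from compound 1 to compound 2 (0.29 log units; within the scatter). Compound 3 shares a part of its core with compound 1, but the difference between the two cores is not broken down here.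

Compound 4 `Clc1cccc(COc2cc3n(n2)CCCC3)n1` is not yet measured. It differs from compound 3 by chloro in place of hydrogen on an aromatic carbon. Among the measured compounds shown here, this is the same kind of change as the one from compound 1 to compound 2, but not the same: in compound 2 the chloro sits two atoms from the ring nitrogen, para to a group of 9 heavy atoms, while in compound 4 it sits next to the ring nitrogen, meta to a large group.

A step of roughly similar size, a 1.7-fold lower number from compound 3 to compound 4 (0.22 log units; within the scatter), is expected from compound 3 to compound 4, because the earlier chloro gave a 1.9-fold lower number from compound 1 to compound 2 (0.29 log units; within the scatter). Given the different place, the estimate is held loosely. Compound 4 is expected to give about 1500 nM in this assay, most likely between 500 nM and 4500 nM.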

Compound 4, half-maximal inhibitory concentration: 5900 nM
Beside the measured number, compound 4's estimate is 3.9-fold (0.59 log units) below it; the whole stated range lies below it.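

Putting chloro in place of hydrogen gave a 2.4-fold higher number from compound 3 to compound 4 (0.37 log units; beyond the scatter) in this assay, so compound 4 is a weaker inhibitor than compound 3. Set beside the earlier step, the same change did not carry over from one core to the other: the same change on two cores in this assay, a 1.9-fold lower number (0.29 log units; within the scatter) from compound 1 to compound 2 and a 2.4-fold higher number (0.37 log units; beyond the scatter) from compound 3 to compound 4, 4.6-fold (0.66 log units) apart, beyond the scatter of two such steps. Among the compounds shown here, with only one pair on each core, and the chloro in a different place in each, this does not show whether the core or the place separates the two steps.

The compounds shown leave open how compound 3 would respond to chloro in another place on its ring. They also leave open whether a methyl or a nitrile in place of the chloro of compound 4 would give a similar number.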